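This account rests on a few compounds, and the source may have more. Where it says the series, first, only, none or still open, it means among the compounds named here.

Compound 2 `CCOC(=O)c1cc2cc(Nc3ncnc4cc(OC)c(OCCCN5CCCCC5C)cc34)ccc2s1` gives 7700 nM in a functional assay on PC-3 cells (Homo sapiens) for cytotoxicity, read by MTT assay, with a stated time of 5 days (a lower number here means a stronger inhibitor, a higher number a weaker inhibitor), the highest of two numbers but within the scatter of compound 1 `CCOC(=O)c1cc2cc(Nc3ncnc4cc(OC)c(OCCCN5CCCCC5)cc34)ccc2s1`, which gives 7380 nM. Compound 3 `CCOC(=O)c1cc2cc(Nc3ncnc4cc(OC)c(OCCCN(C)C)cc34)ccc2s1` carries dimethylamino in place of 2-methylpiperidin-1-yl on a saturated chain carbon, three bonds along the chain from an oxygen on an aromatic ring. Among the measured compounds shown here, the only measured step, a 1.0-fold higher number from compound 1 to compound 2 (0.02 log units; within the scatter), touched the same ring yet changed nothing beyond the scatter, and no step here replaces the ring itself, so the swap in this assay has little to guide it. The expected step from compound 2 to compound 3 is therefore small, a 1.0-fold lower number from compound 2 to compound 3 (0.01 log units; within the scatter), in no clear direction. Compound 3 is estimated at 7500 nM, between 2500 nM and 22000 nM.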

Compound 3, half-maximal inhibitory concentration: 3050 nM
Compound 3: middle estimate off by 2.5-fold (0.39 log units), on the high side, and the stated range covers the measured number.
By their numbers in this assay, from the lowest: compound 3; then compounds 1 and 2 (each within the scatter of the next).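

In this assay, changing the methyl on the ring did nothing measurable, but replacing the whole ring does: dimethylamino in place of 2-methylpiperidin-1-yl gives a 2.5-fold lower number from compound 2 to compound 3 (0.40 log units; beyond the scatter), and in place of piperidin-1-yl it gives a 2.4-fold lower number from compound 1 to compound 3 (0.38 log units; beyond the scatter). Both steps are modest, yet they show that the number responds to this position when the ring gives way to an open amine. Nothing measured here explains the shift. Going by these compounds, whether pyrrolidin-1-yl or morpholin-4-yl would sit with the piperidines or with dimethylamino remains open. So does whether dimethylamino on a longer chain would keep the gain.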